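The source may report more compounds than this note shows. Statements on the series, on what has been measured and on what is new or still open speak of the compounds shown alone.

Measured so far in a functional assay on HCT-15 cells (Homo sapiens) for cytotoxicity, read by CCK-8 assay; a lower number here means a stronger inhibitor, a higher number a weaker inhibitor:
- Compound 1 `Oc1cccc(-c2cc(-c3cccs3)cc(-c3ccccc3O)n2)c1`: > 50000 nM (a limit)
- Compound 2 `Oc1ccc(-c2cc(-c3cccs3)cc(-c3ccccc3O)n2)cc1`: > 50000 nM (a limit)
- Compound 3 `Oc1cccc(-c2cc(-c3cccs3)cc(-c3cccc(O)c3)n2)c1`: 3480 nM

Compound 1 stands on a limit and not on a number: its reading is the limit of > 50000 nM in this assay, at which 2 of the 3 values shown sit, and compound 2 is the other compound there. Compound 4 `Oc1cccc(-c2cc(-c3ccccn3)cc(-c3ccccc3O)n2)c1` keeps both hydroxyphenyl groups of compound 1 but has pyridin-2-yl in place of thiophen-2-yl on an aromatic carbon, opposite the ring nitrogen: pyridin-2-yl in place of thiophen-2-yl on an aromatic carbon.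

Neither measured step touches that place. The change to 4-hydroxyphenyl gives a step that the two limits leave unreadable from compound 1 to compound 2, and 3-hydroxyphenyl in place of 2-hydroxyphenyl gives an at least 14-fold lower number from compound 1 to compound 3 (1.15 log units; beyond the scatter). That second step is large, but compound 4 keeps the 2-hydroxyphenyl group whose replacement produced it. All three measured compounds carry thiophen-2-yl, so the exchange itself has not been tested in this assay, and no firm size or direction can be drawn for it. Compound 4 is therefore expected to stay close to compound 1, whose limit is > 50000 nM and remains the only anchor. The expected change is an at least 1.2-fold lower number from compound 1 to compound 4 (0.09 log units; that floor lies within the scatter), with no clear shift anticipated. For compound 4 the estimated value is 40000 nM, in an expected range from 10000 nM to 100000 nM.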

Compound 4, half-maximal inhibitory concentration: > 50000 nM
Compound 4 gave a limit, no number (the forecaster's own chance of this, stated with the estimate: 55%); middle value at least 1.2-fold (0.09 log units) away from the limit.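

In this assay compound 4 gives > 50000 nM, a limit and not a number. Compound 1 also reads as a limit, so no step can be read between compound 1 and compound 4, and compound 4 sits with them at that ceiling: the limit of > 50000 nM in this assay, at which 3 of the 4 values shown sit. The compounds shown leave open whether pyridin-2-yl in place of thiophen-2-yl changes the reading at all.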